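Thioether benzamides tested for growth inhibition of liver cancer cells

A few compounds are considered here, and "the series" means these few. Any claim that something is new, unique, unknown or untested is made for them only; others in the source may bear on it.

Measured compounds and values:
compound 1, `COc1ccc(SCc2ccc(/C=C/C(=O)Nc3ccccc3N)cc2)cc1OC`, 14.3%
compound 2, `Nc1ccccc1NC(=O)c1ccc(CSc2nccc(C(F)(F)F)n2)cc1`, 66.1%
compound 3, `Cc1ccc(SCc2ccc(C(=O)Nc3ccccc3N)cc2)cc1`, 25.1%

Three compounds sharing a thioether-linked benzylic core with an aminophenyl amide were measured in a functional assay on SMMC-7721 cells (Homo sapiens) for inhibition, read by CCK-8 assay, with a stated time of 72 h, tested at 2 uM; a higher number here means more inhibition of growth at the concentration tested, a lower number less inhibition of growth. Compound 1 gives 14.3%, the lowest of the three numbers. Its nearest neighbour is compound 3, which gives 25.1%, a gap beyond the usual scatter; the furthest is compound 2, which gives 66.1%, far beyond the scatter.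

Compound 4, `CC(C)(C)c1ccc(SCc2ccc(/C=C/C(=O)Nc3ccccc3N)cc2)cc1`, has not yet been measured in this assay. It differs from compound 1 in one place: 4-(tert-butyl)phenyl in place of 3,4-dimethoxyphenyl on a sulfur. Because compound 1 sits at 14.3%, the lowest point of the set, and compound 3 with a methyl-substituted phenyl thioether sits at 25.1%, the author expects a small upward step from compound 1 to compound 4 in this assay, of a size that may or may not exceed the scatter. The expected step is a number 9.7 percentage points higher from compound 1 to compound 4 (within the scatter). For compound 4 the estimate in this assay is 24%, within a range from 6% to 48%.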

Compound 4, percent growth inhibition at one concentration: 18.3%
Compound 4: middle estimate off by 5.7 percentage points, on the high side, and the stated range covers the measured number.
By their numbers in this assay, from the lowest: compounds 1, 4 and 3 (each within the scatter of the next, the first and the last beyond it); then compound 2.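

In this assay, for the compounds shown here, the two compounds form the first pair in the set that differs in only one place, which allows a single change on the sulfur to be read directly. Putting 4-(tert-butyl)phenyl in place of 3,4-dimethoxyphenyl on a sulfur whose other neighbour is a saturated chain carbon gives a number 4 percentage points higher from compound 1 to compound 4 (within the scatter) and so shows no readable effect of this exchange, even though the entering group has the same count of heavy atoms, all carbon, and no hydrogen-bond acceptors where the leaving group has two oxygens and two such acceptors. Nothing given here accounts for this outcome or tests what lies behind it.

A single step at one position and one concentration cannot show whether the same insensitivity would hold for every group on this sulfur. Going by these compounds, it remains open whether a phenyl ring carrying an amine or a carboxylic acid, or a longer chain in its place, would shift the number in this assay beyond the usual scatter.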